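Trimming a Chain: From Allyl to Ethyl

The source may report more compounds than this note shows. Statements on the series, on what has been measured and on what is new or still open speak of the compounds shown alone.

Compound 1, `C=CCn1c(SCC(=O)c2ccccc2)nnc1-c1ccc(OC)c(OC)c1`, has been tested in a functional assay on the whole organism (strain albino) for inhibition, with Rattus norvegicus as the target, read by paw edema, with a stated time of 5 h, at a dose of 0.28 mmol/kg by the oral route (a higher number here means more inhibition at the dose given (going by the name of the read-out), a lower number less inhibition), where compound 1 gives 62%. Going by the values given here, the only other measured compound is compound 2, `C=CCn1c(SCC(=O)c2ccccc2)nnc1-c1ccc(OC)cc1`, which in this assay gives 61%. The step of a number 1 percentage points lower from compound 1 to compound 2 (within the scatter) is within the scatter, so the two compounds cannot be told apart on these numbers; the structural difference between them is hydrogen in place of methoxy on an aromatic carbon.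

Compound 3, `CCn1c(SCC(=O)c2ccccc2)nnc1-c1ccc(OC)c(OC)c1`, has not yet been measured. It differs from compound 1 in one place: methyl in place of vinyl on a saturated chain carbon bound to an aromatic nitrogen. Among the compounds with values here, this change sits on the chain bound to the aromatic nitrogen, a part of the molecule that no measured step touches; the single step available concerns the methoxy group and bears no information on the chain. With nothing to lean on, no shift beyond the scatter is expected in this assay, and the step of a number 4 percentage points lower from compound 1 to compound 3 (within the scatter) is expected to be small. Compound 3 is estimated at 58%, with a range from 45% to 70%.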

Compound 3, a percentage reported as inhibition, in the whole organism at one dose (the size of the read-out at that dose, not a potency): 69%
The estimate for compound 3 lay 11 percentage points below the measured number; the range from low to high includes it.
By their numbers in this assay, from the lowest: compounds 2, 1 and 3 (each within the scatter of the next).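

Going by these compounds alone, the step of a number 7 percentage points higher from compound 1 to compound 3 (within the scatter) in this assay is the first reading on the chain bound to the aromatic nitrogen, a part of the molecule the earlier comparison did not touch. It lies within the scatter, so in this pair the allyl chain, with its double bond outside aromatic rings, can be replaced by the shorter ethyl chain without a change that can be told apart from repeat-to-repeat variation. The available data contain nothing that would explain how this chain relates to the read-out.

As far as these compounds go, what a much longer chain, such as hexyl, or a chain ending in an amine or a carboxylic acid, would do at this position remains open, since allyl and ethyl sample only a small range of chains. It is also open whether the same change would read alike with the single methoxy group of compound 2, and, as each number comes from one dose, how the potencies of these compounds compare.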